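Cinnamyl ester series: chlorination of the ester-side aryl

A few compounds are considered here, and "the series" means these few. Any claim that something is new, unique, unknown or untested is made for them only; others in the source may bear on it.

Measured so far:
compound 1 `CC1=NC(C)=C(C(=O)O)C(c2cccc(Cl)c2)/C1=C(\O)OC/C=C/c1ccccc1` — 1000 nM
compound 2 `CC1=NC(C)=C(C(=O)O)C(c2cccc(Br)c2)/C1=C(\O)OC/C=C/c1ccccc1` — 790 nM
compound 3 `CC1=NC(C)=C(C(=O)O)C(c2cccnc2)/C1=C(\O)OC/C=C/c1ccccc1` — 24000 nM

In a functional assay on IMR-32 cells for inhibition of Voltage-dependent N-type calcium channel subunit alpha-1B (Homo sapiens), read by calcium flux (on this read-out lower numbers stand for stronger inhibition and higher numbers for weaker inhibition), compound 1 gives 1000 nM, the second highest of the three numbers. Its nearest neighbour is compound 2: a 1.3-fold lower number from compound 1 to compound 2 (0.10 log units; within the scatter). Its furthest is compound 3: a 24-fold higher number from compound 1 to compound 3 (1.38 log units; beyond the scatter); the same replacement reads a 30-fold higher number from compound 2 to compound 3 (1.48 log units; beyond the scatter).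

Compound 4 `CC1=NC(C)=C(C(=O)O)C(c2cccc(Cl)c2)/C1=C(\O)OC/C=C/c1ccc(Cl)cc1` differs from compound 1 by chloro in place of hydrogen on an aromatic carbon: the chloro enters on an aromatic carbon of the six-membered aromatic ring of carbon only, para to a large group, so that the 3-phenylprop-2-en-1-yl ester becomes 3-(4-chlorophenyl)prop-2-en-1-yl. Going by the values given here, none of the measured steps touches this ring. The two known changes both sit on the aryl attached to the saturated ring carbon, where swapping chloro for bromo stayed within the scatter and pyridin-3-yl for the halophenyl cost a great deal. Among the compounds with values here, no step therefore bears directly on compound 4, and the expectation in this assay is a small step at most, of uncertain direction, most likely none beyond the scatter.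

For compound 4 the estimate in this assay is 800 nM, range 250 nM to 2500 nM, corresponding to an expected 1.3-fold lower number from compound 1 to compound 4 (0.10 log units; within the scatter).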

Compound 4, half-maximal inhibitory concentration: 1500 nM
Compound 4: middle estimate off by 1.9-fold (0.27 log units), on the low side; low and high end bracket the measured number.
By their numbers in this assay, from the lowest: compounds 2, 1 and 4 (each within the scatter of the next); then compound 3.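

Going by these compounds alone, this is the first reading on the ester-side ring: in the assay (this assay), the change from phenyl to 4-chlorophenyl in the 3-phenylprop-2-en-1-yl ester gives a step within the scatter (a 1.5-fold higher number from compound 1 to compound 4 (0.18 log units; within the scatter)). This position therefore accepts a chloro on the aromatic carbon para to a large group with no change that can be told from the scatter, whereas replacing the 3-chlorophenyl on the saturated ring carbon with pyridin-3-yl gives a large step (a 24-fold higher number from compound 1 to compound 3 (1.38 log units; beyond the scatter)). No measurement at hand accounts for this difference between the two rings.

The compounds shown leave open whether this carbon also accepts groups other than a halogen, such as a methoxy, an amine or a carboxylic acid, and whether a chloro on another carbon of the same ring reads the same. Also open, going by these compounds, is whether a longer chain in place of the prop-2-en-1-yl link, or a pyridin-3-yl in place of the ester-side phenyl, keeps the number of compound 1 within the scatter.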